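Lipophilicity notes on the aryl replacement series

The compounds below may be only part of what the source reports. "The series", "measured", "known", "first", "only" and "open" are said of these compounds alone.

Measured in a physicochemical assay for lipophilicity, measured as octanol-water partition; a higher number here means a more lipophilic compound, a lower number a more polar compound:
compound 1, `Cc1c(NCc2nnc(COc3ccccc3)o2)c(=O)n(-c2ccccc2)n1C`, gives 0.98
compound 2, `Cc1c(NCc2nnc(-c3ccc(Cl)cc3)o2)c(=O)n(-c2ccccc2)n1C`, gives 2.7
compound 3, `Cc1ccc(-c2nnc(CNc3c(C)n(C)n(-c4ccccc4)c3=O)o2)cc1`, gives 2.48

Compound 1 stands lowest of the three numbers; compound 3 is nearest to it and compound 2 furthest, both beyond the scatter. Compound 4, `Cc1cccc(-c2nnc(CNc3c(C)n(C)n(-c4ccccc4)c3=O)o2)c1`, is not yet measured in this assay. Relative to compound 1 the change is 3-methylphenyl in place of phenoxymethyl on an aromatic carbon.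

For the measured compounds named here, two measured steps bear directly on this move, both starting from the same leaving group: a number 1.72 log units higher from compound 1 to compound 2 (beyond the scatter) and a number 1.50 log units higher from compound 1 to compound 3 (beyond the scatter). Both are large and point the same way. Between the two arylated compounds the difference is a number 0.22 log units lower from compound 2 to compound 3 (within the scatter), so whether the aryl carries methyl or chloro is not separated by this assay. Compound 4 carries the same leaving group as compound 1 and the same entering methylphenyl as compound 3, only with the methyl at another position on the aromatic ring. A large upward step in this assay is therefore expected, and the estimated step is a number 1.52 log units higher from compound 1 to compound 4 (beyond the scatter). Compound 4 is expected to come out near 2.5, with a plausible range from 2.1 to 2.9.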

Compound 4, partition coefficient: 2.39
Estimate against measurement, compound 4: 0.11 log units above, and the stated range covers the measured number.
By their numbers in this assay, from the lowest: compound 1; then compounds 4, 3 and 2 (each within the scatter of the next, the first and the last beyond it).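

In this assay, the large upward step does not depend on the methyl sitting as in 4-methylphenyl: a number 1.41 log units higher from compound 1 to compound 4 (beyond the scatter) is of the same large size, and a number 0.09 log units lower from compound 3 to compound 4 (within the scatter) leaves the two methylphenyl isomers unseparated. Against 4-chlorophenyl the picture is slightly different, since a number 0.31 log units lower from compound 2 to compound 4 (beyond the scatter) is a modest step, whereas a number 0.22 log units lower from compound 2 to compound 3 (within the scatter) kept the two groups apart by no more than the scatter. Among the aryl compounds, then, only the pair of compound 2 and compound 4 is separated, and this modest gap is small beside the large steps up from compound 1.

As far as these compounds go, whether the large step belongs to the oxygen of phenoxymethyl or to the whole chain stays open, as does what a benzyl group, an amine or a carboxylic acid would give on the same aromatic carbon. No measured evidence in hand accounts for any of these steps.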